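This account rests on a few compounds, and the source may have more. Where it says the series, first, only, none or still open, it means among the compounds named here.

Working notes on the series in an ADME assay on HUVEC cells (Homo sapiens) for antiproliferative activity, read by MTT assay, with a stated time of 48 h; a higher number here means a weaker inhibitor, a lower number a stronger inhibitor.

Compound 2, `N#CC1=C(N)Oc2c(N)cc3nc4ccccc4nc3c2C12C(=O)N(Cc1cnnn1-c1ccccc1Cl)c1ccccc12`, stands only at a limit in this assay: compound 2 gives > 50000 nM, which is a limit of the assay and not a number. Its neighbour compound 1, `Cc1cccc(-n2nncc2CN2C(=O)C3(C(C#N)=C(N)Oc4c(N)cc5nc6ccccc6nc5c43)c3ccccc32)c1`, sits the same way: in this assay compound 1 gives > 50000 nM, again a limit. Within the data shown here, the single measured step, a step that the two limits leave unreadable from compound 1 to compound 2, is therefore unreadable in size and direction, and what the two values share is stated by the limit of > 50000 nM in this assay, at which 2 of the 2 values shown sit.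

Compound 3, `N#CC1=C(N)Oc2c(N)cc3nc4ccccc4nc3c2C12C(=O)N(Cc1cnnn1-c1cccc(Br)c1)c1ccccc12`, is not yet measured. It differs from compound 2 in one place: 3-bromophenyl in place of 2-chlorophenyl on an aromatic nitrogen. Among the measured compounds shown here, the only measured step on this aromatic nitrogen, from compound 1 to compound 2, cannot be read, so no size or direction can be taken from it; what can be said is that both compounds bearing a substituted phenyl at this position sit at the limit. On that basis compound 3 is expected to behave alike, with an estimated step that the limit leaves unreadable from compound 2 to compound 3 that cannot be distinguished from none. The estimate for compound 3 in this assay is 80000 nM, in the range 20000 nM to 300000 nM, with a limit being the most likely report.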

Compound 3, half-maximal inhibitory concentration: > 50000 nM
Compound 3: a limit, no number; the forecaster's own chance of this, stated with the estimate: 75%; the middle value does not contradict the limit.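

In this assay compound 3 gives > 50000 nM, a limit and not a number, so neither step to compound 3, from compound 1 or from compound 2, can be read in size or direction. The compounds shown leave open whether the substituted phenyl groups on the aromatic nitrogen differ at all in this assay: the limit of > 50000 nM in this assay, at which 3 of the 3 values shown sit.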